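A few compounds are considered here, and "the series" means these few. Any claim that something is new, unique, unknown or untested is made for them only; others in the source may bear on it.

Measured compounds:
Compound 1 `CC(=O)N1N=C(c2ccc(F)cc2)CC1c1cn(-c2ccccc2)nc1-c1ccc(Cl)cc1`; in a functional assay on the whole organism (Tail) with Rattus norvegicus as the target, in the tail flick test, with a stated time of 60 min, at a dose of 25 mg/kg by the oral route (on this read-out higher numbers stand for more inhibition at the one dose given (going by the name of the read-out) and lower numbers for less inhibition), compound 1 gives 44%.
Compound 2 `CC(=O)N1N=C(c2ccc(F)cc2)CC1c1cn(-c2ccccc2)nc1-c1ccc(C)cc1`; in this assay compound 2 gives 110%.
Compound 3 `CC(=O)N1N=C(c2ccc(F)cc2)CC1c1cn(-c2ccccc2)nc1-c1cccc([N+](=O)[O-])c1`; in this assay compound 3 gives 109%.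

Compound 2 holds the highest number of the three, though the gap to compound 3 is within the scatter (a number 1 percentage points lower from compound 2 to compound 3 (within the scatter)), while compound 1 lies well below it (a number 66 percentage points higher from compound 1 to compound 2 (beyond the scatter)). Compound 4 `Cc1ccc(-c2nn(-c3ccccc3)cc2C2CC(c3ccc(F)cc3)=NN2c2ccccc2)cc1` differs from compound 2 in one place: phenyl in place of acetyl on an amine nitrogen in a ring. Among the compounds with values here, every measured step changes the aryl group on an aromatic carbon; no step touches the amine nitrogen in the ring, so none bears on this change. The estimate therefore rests on compound 2 alone, with a wide range. The expected step is a number 25 percentage points lower from compound 2 to compound 4 (beyond the scatter). Compound 4 is estimated at 85%, between 40% and 115%.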

Compound 4, a percentage reported as inhibition, in the whole organism at one dose (the size of the read-out at that dose, not a potency): 110%
Compound 4: middle estimate off by 25 percentage points, on the low side, within the range that was stated.
By their numbers in this assay, from the lowest: compound 1; then compounds 3, 2 and 4 (each within the scatter of the next).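

Within the data shown here, at the amine nitrogen in the ring, phenyl in place of acetyl in this assay gives no change at the digits printed from compound 2 to compound 4 (within the scatter) and so provides the first reading at this position. With the 4-methylphenyl group in place, acetyl is not needed for this level of inhibition, and the two groups cannot be told apart at this dose. No measurement on hand gives a reason for this result.

Still open, on these data alone, is how methyl, butanoyl or a phenyl bearing a carboxylic acid would read at this nitrogen. Also open, as far as these compounds go, is whether phenyl here would give a similar reading alongside the 4-chlorophenyl group of compound 1.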